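Swapping Methyl for Cyclopentyl on the Aromatic Nitrogen

The source may hold more compounds than are shown below. What is called first, only, known or untested is meant among the compounds shown, and "the series" means these compounds.

Of the compounds shown here, three built on one shared core have been tested in a functional assay on the whole organism for inhibition, with Rattus norvegicus as the target, at a dose of 25 mg/kg by the intraperitoneal route; on this read-out higher numbers stand for more inhibition at the one dose given (going by the name of the read-out) and lower numbers for less inhibition. Compound 1 `CN(C)c1ncnc2c1ncn2Cc1ccccc1[N+](=O)[O-]` gives 0% in this assay. Compound 2 `CN(C)c1ncnc2c1ncn2CC1CCCCC1` gives 0% in this assay. Compound 3 `CN(C)c1ncnc2c1ncn2C` gives 30% in this assay, the highest of the three numbers, and its steps to both other compounds lie beyond the scatter.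

The unmeasured compound 4 `CN(C)c1ncnc2c1ncn2C1CCCC1` differs from compound 3 in one place: cyclopentyl in place of methyl on an aromatic nitrogen. Within the data shown here, one measured step bears on this change: a number 30 percentage points higher from compound 2 to compound 3 (beyond the scatter). There, removing a ring that hung from the saturated chain carbon bound to the aromatic nitrogen raised the read-out. Compound 4 brings a ring back, now as cyclopentyl set directly on the aromatic nitrogen with no chain carbon between. Among the measured compounds shown here, the parallel is loose, since the earlier change touched a group on a chain carbon rather than the nitrogen itself, yet it is the only guide available. The expectation is therefore a downward step in this assay, of the size a number 20 percentage points lower from compound 3 to compound 4 (beyond the scatter). Compound 4 is expected to give about 10% in this assay, with a range from 0% to 30%.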

Compound 4, a percentage reported as inhibition, in the whole organism at one dose (the size of the read-out at that dose, not a potency): 27%
For compound 4 the middle estimate is 17 percentage points below the measured one; measured number inside the range.
By their numbers in this assay, from the lowest: compounds 1 and 2 (each within the scatter of the next); then compounds 4 and 3 (each within the scatter of the next).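

In this assay, cyclopentyl in place of methyl on the aromatic nitrogen gives a number 3 percentage points lower from compound 3 to compound 4 (within the scatter), so a whole ring of carbon can stand at this position with no change that can be told from the usual scatter. The earlier compounds shown here could have suggested that any ring here takes the read-out down, but that does not hold: compound 2, with cyclohexyl on a chain carbon bound to the aromatic nitrogen, gives 0%, while compound 4, with its ring set directly on that nitrogen, gives 27%. Nothing at hand explains why these two compounds give such different numbers, and no measurement speaks to a cause.

The compounds shown do not tell whether the chain carbon or the size of the ring accounts for that gap, and cyclohexyl set directly on the aromatic nitrogen, or cyclopentyl carried on a chain carbon, would separate the two. They also leave open what a straight butyl chain or a chain ending in a carboxylic acid would give at this position, and each number describes one dose only, so none of them is a potency.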